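The source may report more compounds than this note shows. Statements on the series, on what has been measured and on what is new or still open speak of the compounds shown alone.

Compound 1 `CC1=NN(c2ccc(Cl)cc2)C(=O)C12C=CC(=O)C=C2c1ccccc1` reaches only the limit > 100000 nM in a functional assay on HCT-116 cells (Homo sapiens) for antiproliferative activity, read by CCK-8 assay, with a stated time of 72 h; a higher number here means a weaker inhibitor, a lower number a stronger inhibitor. Compound 2 `CC1=NN(c2ccc(Cl)cc2)C(=O)C12C=CC(=O)C=C2c1ccc(C)cc1` gives 10300 nM in this assay.

Within the data shown here, compound 2 thus holds the only actual number in this assay, the other value being a limit. The step from compound 1 to compound 2 is an at least 9.7-fold lower number from compound 1 to compound 2 (0.98 log units; beyond the scatter), though it rests on the limit of > 100000 nM in this assay, at which 1 of the 2 values shown sits, and is known only as a bound. Compound 3 `CC1=NN(c2ccc(Cl)cc2)C(=O)C12C=CC(=O)C=C2c1cccc(C)c1` differs from compound 2 by 3-methylphenyl in place of 4-methylphenyl on a double-bonded ring carbon. Among the measured compounds shown here, no measured step moves the methyl around the ring, so no clear direction can be drawn. Compound 3 is estimated at 12000 nM, between 4000 nM and 40000 nM, a step of a 1.2-fold higher number from compound 2 to compound 3 (0.07 log units; within the scatter) that is expected to stay within the scatter.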

Compound 3, half-maximal inhibitory concentration: 13300 nM
For compound 3 the middle estimate is 1.1-fold (0.04 log units) below the measured one; measured number inside the range.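

In this assay, 3-methylphenyl in place of 4-methylphenyl on the double-bonded ring carbon gives a 1.3-fold higher number from compound 2 to compound 3 (0.11 log units; within the scatter), so the two placements of the methyl are not told apart here. The step of an at least 7.5-fold lower number from compound 1 to compound 3 (0.87 log units; beyond the scatter) shows that the lower number seen with the 4-methylphenyl group also appears with the 3-methylphenyl group. Compound 1 stands at a limit rather than a number, so the true size of that step stays unknown: the limit of > 100000 nM in this assay, at which 1 of the 3 values shown sits.

The compounds shown leave open how 2-methylphenyl would compare. They also leave open whether a methoxy group or an amine on this aromatic ring would give a lower number than methyl.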